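The source may hold more compounds than are shown below. What is called first, only, known or untested is meant among the compounds shown, and "the series" means these compounds.

Compound 2 `CCCn1c(=O)n(C)c(=O)c2c1ncn2CCC(=O)O` stands in an assay on Cerebral cortex for binding affinity to adenosine receptor A1 (Cavia porcellus), read by radioligand binding (a higher number here means a weaker inhibitor, a lower number a stronger inhibitor), only at a limit, > 200000 nM, so no number is known for it (the limit of > 200000 nM in this assay, at which 1 of the 2 values shown sits). Compound 1 `CCCn1c(=O)n(CCCCC(C)=O)c(=O)c2[nH]cnc21` differs from compound 2 in several places. In this assay compound 1 gives 23100 nM. Compound 3 `CCCn1c(=O)n(C)c(=O)c2c1ncn2CC#N` carries cyano in place of carboxymethyl on a saturated chain carbon bound to an aromatic nitrogen; the same difference, cut one bond further out, reads 2-carboxyethyl to cyanomethyl. For the measured compounds named here, no measured step covers this change, so only an expectation is possible. The expected step of an at least 4.0-fold lower number from compound 2 to compound 3 (0.60 log units; beyond the scatter) points toward stronger binding, clearly beyond the scatter. For compound 3 the estimate in this assay is 50000 nM, within 10000 nM to 200000 nM.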

Compound 3, inhibition constant: 6600 nM
Beside the measured number, compound 3's estimate is 7.6-fold (0.88 log units) above it, outside the stated range (below it).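

In this assay, cyano in place of carboxymethyl on a saturated chain carbon bound to an aromatic nitrogen gives an at least 30-fold lower number from compound 2 to compound 3 (1.48 log units; beyond the scatter). This place on the shared core can therefore carry a group that gives a measured number, which compound 2 did not show. Compound 2 stands only at a limit, so the step is a bound and not an exact size: the limit of > 200000 nM in this assay, at which 1 of the 3 values shown sits.

Going by these compounds, whether the step comes from the loss of carboxymethyl or from the cyano itself stays open. An amide or a longer chain ending in a nitrile at this place would help to separate the two.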